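This account rests on a few compounds, and the source may have more. Where it says the series, first, only, none or still open, it means among the compounds named here.

Measured compounds:
Compound 1, `CCN(CC)c1ccc(/C=N/NC(=O)Nc2cc3c(Nc4ccc(F)c(Cl)c4)ncnc3cc2O[C@H]2CCOC2)c(O)c1` — 15700 nM
Compound 2, `O=C(N/N=C/c1ccc(O)cc1)Nc1cc2c(Nc3ccc(F)c(Cl)c3)ncnc2cc1O[C@H]1CCOC1` — 70 nM
Compound 3, `CCN(CC)c1ccc(/C=N/NC(=O)Nc2cc3c(Nc4ccc(F)c(Cl)c4)ncnc3cc2OC)c(O)c1` — 29300 nM

In a functional assay on HepG2 cells (Homo sapiens) for cytotoxicity, read by MTT assay, with a stated time of 72 h (on this read-out higher numbers stand for weaker inhibition and lower numbers for stronger inhibition), compound 1 gives 15700 nM and compound 2 gives 70 nM. The change between them is 4-hydroxyphenyl in place of 4-(diethylamino)-2-hydroxyphenyl on a carbon with a double bond to nitrogen, and it made a step of a 220-fold lower number from compound 1 to compound 2 (2.35 log units; beyond the scatter). Compound 3, `CCN(CC)c1ccc(/C=N/NC(=O)Nc2cc3c(Nc4ccc(F)c(Cl)c4)ncnc3cc2OC)c(O)c1`, gives 29300 nM in this assay; it differs from compound 1 by methyl in place of oxolan-3-yl on an oxygen on an aromatic ring, a step of a 1.9-fold higher number from compound 1 to compound 3 (0.27 log units; within the scatter). Compound 4, `COc1cc2ncnc(Nc3ccc(F)c(Cl)c3)c2cc1NC(=O)N/N=C/c1ccc(O)cc1`, is not yet measured. It differs from compound 3 by 4-hydroxyphenyl in place of 4-(diethylamino)-2-hydroxyphenyl on a carbon with a double bond to nitrogen, the same change as that from compound 1 to compound 2, at the same place. Compound 3 stands close to compound 1, with compound 3 at 29300 nM, so the step from compound 3 to compound 4 is expected to be about a 230-fold lower number from compound 3 to compound 4 (2.35 log units; beyond the scatter), resting on the step of a 220-fold lower number from compound 1 to compound 2 (2.35 log units; beyond the scatter). Compound 4 is therefore estimated at 130 nM, with a range from 40 nM to 450 nM.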

Compound 4, half-maximal inhibitory concentration: 26300 nM
Beside the measured number, compound 4's estimate is 200-fold (2.31 log units) below it, outside the stated range (above it).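

In this assay the change to 4-hydroxyphenyl did not carry from one core to the other: the same change on two cores in this assay, a 220-fold lower number (2.35 log units; beyond the scatter) from compound 1 to compound 2 and a 1.1-fold lower number (0.05 log units; within the scatter) from compound 3 to compound 4, 200-fold (2.30 log units) apart, beyond the scatter of two such steps. The new step is a 1.1-fold lower number from compound 3 to compound 4 (0.05 log units; within the scatter), whereas methyl in place of oxolan-3-yl on an oxygen on an aromatic ring gives a 380-fold higher number from compound 2 to compound 4 (2.57 log units; beyond the scatter), so this change also depended on its setting: the same change on two cores in this assay, a 1.9-fold higher number (0.27 log units; within the scatter) from compound 1 to compound 3 and a 380-fold higher number (2.57 log units; beyond the scatter) from compound 2 to compound 4, 200-fold (2.30 log units) apart, beyond the scatter of two such steps. The two changes therefore do not add up independently in these four compounds, but the data do not show why.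

Going by these compounds, it remains open whether 2-hydroxyphenyl or 4-(diethylamino)phenyl would behave like either group compared here. On these data alone, it is also open whether an ethyl group or a longer chain on that oxygen would follow methyl or oxolan-3-yl.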